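Swapping a Triazole for a Methylpiperidine on a Kinase Inhibitor

This account rests on a few compounds, and the source may have more. Where it says the series, first, only, none or still open, it means among the compounds named here.

Compound 1 `CN1CCN(C(=O)c2ccc(Nc3ncc(C4CC4)c(NCCCNC(=O)C4CCC4)n3)cc2)CC1`: 2 nM
Compound 2 `O=C(NCCCNc1nc(Nc2ccc(-n3cncn3)cc2)ncc1C1CC1)C1CCC1`: 3 nM

Both numbers come from an assay on isolated protein for inhibition of serine/threonine-protein kinase TBK1 (Homo sapiens); a lower number here means a stronger inhibitor, a higher number a weaker inhibitor. Compound 2 sits alongside compound 1 within the usual scatter, so neither can be called the stronger inhibitor. Compound 3 `CN1CCC(c2ccc(Nc3ncc(C4CC4)c(NCCCNC(=O)C4CCC4)n3)cc2)CC1` carries 1-methylpiperidin-4-yl in place of 1H-1,2,4-triazol-1-yl on an aromatic carbon. Among the compounds with values here, the only measured step, a 1.5-fold higher number from compound 1 to compound 2 (0.18 log units; within the scatter), shows that changing this group has so far made little difference. Compound 3 is therefore expected to show a 1.2-fold lower number from compound 2 to compound 3 (0.08 log units; within the scatter), no real change beyond the scatter. The estimate for compound 3 is 2.5 nM, with a likely range from 1 nM to 8 nM.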

Compound 3, half-maximal inhibitory concentration: 8 nM
Compound 3: middle estimate off by 3.2-fold (0.51 log units), on the low side; the measured number falls inside the stated range.
By their numbers in this assay, from the lowest: compounds 1 and 2 (each within the scatter of the next); then compound 3.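

In this assay, within the data shown here, the group at this position does matter: 1-methylpiperidin-4-yl gives a 2.7-fold higher number from compound 2 to compound 3 (0.43 log units; beyond the scatter) and a 4.0-fold higher number from compound 1 to compound 3 (0.60 log units; beyond the scatter) as the first steps here beyond the scatter. Both steps are modest, so strong inhibition survives with a non-aromatic ring on this aromatic carbon. Nothing available explains the rise.

The compounds shown leave open whether the ring or its methyl group sets the number. A piperidin-4-yl group without the methyl, or a morpholin-4-yl group, would bear on that question.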